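This account rests on a few compounds, and the source may have more. Where it says the series, first, only, none or still open, it means among the compounds named here.

Compound 2 `C=C1C(=O)[C@]23C[C@@]1(O)CC[C@H]2c1ccc(O)c(C)c1[C@@H]3Cn1cc(-c2ccccn2)nn1` carries a free hydroxyl on its aromatic ring and a pyridin-2-yl group on the triazole. In a functional assay on MCF7 cells (Homo sapiens) for cytotoxicity, read by MTT assay, with a stated time of 4 days (on this read-out higher numbers stand for weaker inhibition and lower numbers for stronger inhibition), compound 2 gives 2240 nM, the higher of the two numbers measured here. Among the measured compounds shown here, compound 1 `C=C1C(=O)[C@]23C[C@@]1(O)CC[C@H]2c1ccc(OS(=O)(=O)c2ccc(C)cc2)c(C)c1[C@@H]3Cn1cc(-c2ccccn2)nn1`, its (4-methylphenyl)sulfonyl ester, gives 320 nM in this assay; the step of a 7.0-fold higher number from compound 1 to compound 2 (0.85 log units; beyond the scatter) is the only measured step in the set. For the measured compounds named here, compound 3 `C=C1C[C@]23C[C@@]1(O)CC[C@H]2c1ccc(O)c(C)c1[C@@H]3Cn1cc(-c2ccc(Br)cc2)nn1` reaches only the limit of this assay, > 20000 nM, which is a limit and not a number (the limit of > 20000 nM in this assay, at which 1 of the 3 values shown sits); it differs from compound 2 in two places, so no single step connects them.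

Compound 4 `C=C1C(=O)[C@]23C[C@@]1(O)CC[C@H]2c1ccc(O)c(C)c1[C@@H]3Cn1cc(-c2ccc(C)cc2)nn1` is reached from compound 2 by 4-methylphenyl in place of pyridin-2-yl on an aromatic carbon. Going by the values given here, no measured step touches the group on the triazole, so nothing here tells how large a step to expect in this assay, in either direction. Compound 4 is therefore expected to stay close to compound 2, with the step of a 1.3-fold higher number from compound 2 to compound 4 (0.13 log units; within the scatter) taken as lying within the scatter, and its estimated value is 3000 nM, ranging from 900 nM to 12000 nM.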

Compound 4, half-maximal inhibitory concentration: 370 nM
Estimate against measurement, compound 4: 8.1-fold (0.91 log units) above; measured number outside the range, below it.
By their numbers in this assay, from the lowest: compounds 1 and 4 (each within the scatter of the next); then compound 2. At a limit, above all of these: compound 3.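

The group on the five-membered aromatic ring with 3 nitrogen proves to be a position that matters in this assay, since the number falls beyond the scatter in the step of a 6.1-fold lower number from compound 2 to compound 4 (0.78 log units; beyond the scatter). Among the compounds shown here, until now the only measured step lay on the oxygen on the aromatic ring, and this one shows that pyridin-2-yl is not needed here, as 4-methylphenyl gives the lower number with the hydroxyl still free. Nothing measured here accounts for this step.

From the compounds shown here alone, the loss of the ring nitrogen and the gain of the methyl come together, so it stays open whether a plain phenyl or a 4-aminophenyl group would match compound 4. Going by these compounds, it is also open whether a (4-methylphenyl)sulfonyl ester on compound 4 would lower the number further, as it does on compound 2.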